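A few compounds are considered here, and "the series" means these few. Any claim that something is new, unique, unknown or untested is made for them only; others in the source may bear on it.

Three carbonate esters built on one shared core were followed in an ADME assay for pharmacokinetics; a lower number here means that the compound disappears faster, a higher number that the compound lasts longer. Compound 1 `Cc1cn(C2CC(N=[N+]=[N-])C(COC(=O)OCCCO)O2)c(=O)[nH]c1=O` gives 0.167 h, compound 2 `Cc1cn(C2CC(N=[N+]=[N-])C(COC(=O)OCCCCCO)O2)c(=O)[nH]c1=O` gives 0.267 h, and compound 3 `Cc1cn(C2CC(N=[N+]=[N-])C(COC(=O)OCCCCCCO)O2)c(=O)[nH]c1=O` gives 0.117 h. Compound 2 carries 2-hydroxyethyl in place of hydroxy on a saturated chain carbon, three bonds along the chain from an oxygen next to a carbonyl group, a change that made a 1.6-fold higher number from compound 1 to compound 2 (0.20 log units; within the scatter). Compound 3 differs from compound 1 by 3-hydroxypropyl in place of hydroxy on a saturated chain carbon, three bonds along the chain from an oxygen next to a carbonyl group, giving a 1.4-fold lower number from compound 1 to compound 3 (0.15 log units; within the scatter), while a 2.3-fold lower number from compound 2 to compound 3 (0.36 log units; beyond the scatter). Compound 4 `Cc1cn(C2CC(N=[N+]=[N-])C(COC(=O)OCCCCCCCCO)O2)c(=O)[nH]c1=O` is still unmeasured; relative to compound 3 it carries 2-hydroxyethyl in place of hydroxy on a saturated chain carbon, six bonds along the chain from an oxygen next to a carbonyl group. This is the same kind of change as that from compound 1 to compound 2, but the place differs: three bonds along the chain from an oxygen next to a carbonyl group there, six bonds along the chain from an oxygen next to a carbonyl group here. Because the earlier step of a 1.6-fold higher number from compound 1 to compound 2 (0.20 log units; within the scatter) stayed small, compound 4 is expected to show a 1.3-fold higher number from compound 3 to compound 4 (0.11 log units; within the scatter). Compound 4 is therefore estimated at 0.15 h, from 0.07 h to 0.32 h.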

Compound 4, half-life: 0.0333 h
Estimate against measurement, compound 4: 4.5-fold (0.65 log units) above; measured number outside the range, below it.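

In this assay, the 2-hydroxyethyl change did not carry over unchanged from one core to the other, and a 3.5-fold lower number from compound 3 to compound 4 (0.55 log units; beyond the scatter) departs from its earlier counterpart: the same change on two cores in this assay, a 1.6-fold higher number (0.20 log units; within the scatter) from compound 1 to compound 2 and a 3.5-fold lower number (0.55 log units; beyond the scatter) from compound 3 to compound 4, 5.6-fold (0.75 log units) apart, beyond the scatter of two such steps.
The 3-hydroxypropyl change behaved likewise, with an 8.0-fold lower number from compound 2 to compound 4 (0.90 log units; beyond the scatter) set against the earlier step: the same change on two cores in this assay, a 1.4-fold lower number (0.15 log units; within the scatter) from compound 1 to compound 3 and an 8.0-fold lower number (0.90 log units; beyond the scatter) from compound 2 to compound 4, 5.6-fold (0.75 log units) apart, beyond the scatter of two such steps.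
With a 5.0-fold lower number from compound 1 to compound 4 (0.70 log units; beyond the scatter) as well, these steps show that the effect of adding to the chain depends on the chain it starts from, but each comparison rests on a single pair and shows no reason for the difference, nor a rule for other cores.

Going by these compounds, whether a longer chain would last for a still shorter time stays open. So does whether an amine or a carboxylic acid in place of the terminal hydroxy would change the half-life at these chain lengths.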